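TRPV1 antagonist series: replacing the arylamino group at the pyridine

The source may report more compounds than this note shows. Statements on the series, on what has been measured and on what is new or still open speak of the compounds shown alone.

Measured so far:
- compound 1 `CC(C(=O)NCc1ccc(C(F)(F)F)nc1NCC1CCN(C(=O)OC(C)(C)C)CC1)c1ccc(NS(C)(=O)=O)c(F)c1`, 19.3 nM
- compound 2 `Cc1ccc(Cl)cc1Nc1nc(C(F)(F)F)ccc1CNC(=O)C(C)c1ccc(NS(C)(=O)=O)c(F)c1`, 14 nM
- compound 3 `C[C@H](C(=O)NCc1ccc(C(F)(F)F)nc1N1CC[C@H](N(C)C)C1)c1ccc(NS(C)(=O)=O)c(F)c1`, 103 nM

In a functional assay on CHO-K1 cells for antagonist activity at transient receptor potential cation channel subfamily V member 1 (Homo sapiens), read by FLIPR (a higher number here means a weaker inhibitor, a lower number a stronger inhibitor), compound 2 stands at the lowest number of the three. Compound 1 sits within the scatter of it, so no order between compound 1 and compound 2 can be read. Compound 3 lies beyond the scatter, at the highest number.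

Compound 4 `CC(C(=O)NCc1ccc(C(F)(F)F)nc1N1CCC(=O)CC1)c1ccc(NS(C)(=O)=O)c(F)c1` is not yet measured. It differs from compound 2 as follows:
4-oxopiperidin-1-yl in place of (5-chloro-2-methylphenyl)amino on an aromatic carbon

Among the compounds with values here, no measured pair isolates this change. Compound 3, which also carries a ring joined through its nitrogen at this position and gives 103 nM, suggests the direction. A step toward a higher number, beyond the scatter, is expected, a 5.7-fold higher number from compound 2 to compound 4 (0.76 log units; beyond the scatter). For compound 4 the estimate is 80 nM, range 25 nM to 250 nM.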

Compound 4, inhibition constant: 91 nM
Beside the measured number, compound 4's estimate is 1.1-fold (0.06 log units) below it, and the stated range covers the measured number.
By their numbers in this assay, from the lowest: compounds 2 and 1 (each within the scatter of the next); then compounds 4 and 3 (each within the scatter of the next).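

Putting 4-oxopiperidin-1-yl in place of (5-chloro-2-methylphenyl)amino on this aromatic carbon gives a 6.5-fold higher number from compound 2 to compound 4 (0.81 log units; beyond the scatter) in this assay, so this position does respond to the group it carries. The change removes an aromatic ring of carbon only and a hydrogen-bond donor together, and this single step cannot assign the rise to either one. No measurement here bears on why the number rises.

The compounds shown leave open which of the two departures carries the difference. A cyclohexylamino group, or a phenyl group joined without the amino nitrogen, would separate them.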